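The source may report more compounds than this note shows. Statements on the series, on what has been measured and on what is new or still open speak of the compounds shown alone.

The three measured compounds and their results:

Compound 1 `O=C1Nc2ccc(S(=O)(=O)N3CCOCC3)cc2/C1=N/NS(=O)(=O)c1ccccc1` gives 13300 nM in a functional assay on HCT-116 cells (Homo sapiens) for cytotoxicity, read by sulforhodamine B assay, with a stated time of 24 h; a lower number here means a stronger inhibitor, a higher number a weaker inhibitor.
Compound 2 `O=C1Nc2ccc(S(=O)(=O)N3CCOCC3)cc2/C1=N/c1ccc(C(=O)O)cc1` gives 23600 nM in this assay.
Compound 3 `O=C1Nc2ccc(S(=O)(=O)N3CCOCC3)cc2/C1=N/c1ccc(Cl)cc1` gives 24300 nM in this assay.

Compound 3 has the highest of the three numbers, but its separation from compound 2 is a 1.0-fold higher number from compound 2 to compound 3 (0.01 log units; within the scatter) and from compound 1 is a 1.8-fold higher number from compound 1 to compound 3 (0.26 log units; within the scatter), so all three sit together within the scatter and none can be called stronger or weaker than another. Compound 4 `O=C1Nc2ccc(S(=O)(=O)N3CCOCC3)cc2/C1=N/Nc1ccccc1` differs from compound 3 in one place: anilino in place of 4-chlorophenyl on a double-bonded nitrogen. Its bearing steps are those at the same double-bonded nitrogen: a 1.8-fold higher number from compound 1 to compound 2 (0.25 log units; within the scatter) and a 1.8-fold higher number from compound 1 to compound 3 (0.26 log units; within the scatter), each within the scatter, together with the step of a 1.0-fold higher number from compound 2 to compound 3 (0.01 log units; within the scatter) at the aromatic carbon, which is flat. Every change so far at this position has left the number essentially where it was, and nothing in the shown data marks the anilino group as behaving differently from the other three substituents. Compound 4 is therefore expected to fall close to compound 3, with the expected step of a 1.4-fold lower number from compound 3 to compound 4 (0.16 log units; within the scatter) lying within the scatter. Compound 4 is estimated at 17000 nM, with a range from 6000 nM to 45000 nM.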

Compound 4, half-maximal inhibitory concentration: 10500 nM
Beside the measured number, compound 4's estimate is 1.6-fold (0.21 log units) above it; the measured number falls inside the stated range.
By their numbers in this assay, from the lowest: compounds 4, 1, 2 and 3 (each within the scatter of the next, the first and the last beyond it).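

Among the compounds shown here, at the double-bonded nitrogen, the substituent now makes a measurable difference in this assay: anilino in place of 4-chlorophenyl gives a 2.3-fold lower number from compound 3 to compound 4 (0.36 log units; beyond the scatter), and anilino in place of 4-carboxyphenyl gives a 2.2-fold lower number from compound 2 to compound 4 (0.35 log units; beyond the scatter), both modest but the first steps here to pass the scatter. Phenyl in place of phenylsulfonyl on an amine nitrogen gives only a 1.3-fold lower number from compound 1 to compound 4 (0.10 log units; within the scatter), which stays within the scatter, so compound 1 and compound 4, which both carry that amine nitrogen, cannot be told apart; compound 1 goes against any clean split by that nitrogen, however, since it also stays within the scatter of compound 2 and compound 3. No measurement here explains the separation of compound 4 from compound 2 and compound 3.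

As far as these compounds go, it remains open whether the amine nitrogen or the unsubstituted phenyl ring of the anilino group accounts for these steps, which a 4-chloroanilino or a 4-carboxyanilino group at the same place would help to separate. The compounds shown also leave open how a simple methylamino group would read there, and whether the steps would hold with a piperidine in place of the morpholine on the sulfonyl group of the shared core.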